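Ester variations on a shared core in a growth assay

The source may hold more compounds than are shown below. What is called first, only, known or untested is meant among the compounds shown, and "the series" means these compounds.

Compound 1 `CC(C)[C@H](N)C(=O)OCC(C)(C)COC1(c2ccc(Cl)cc2)c2ccccc2C(=O)N1Cc1ccc(Cl)cc1`: 40000 nM
Compound 2 `CC(C)(CO)COC1(c2ccc(Cl)cc2)c2ccccc2C(=O)N1Cc1ccc(Cl)cc1`: 65000 nM
Compound 3 `CC(=O)OCC(C)(C)COC1(c2ccc(Cl)cc2)c2ccccc2C(=O)N1Cc1ccc(Cl)cc1`: 70000 nM

In a functional assay on HCT-116 cells (Homo sapiens) for inhibition, read by fluorescence, with a stated time of 48 h (a higher number here means a weaker inhibitor of growth, a lower number a stronger inhibitor of growth), compound 3 gives 70000 nM, the highest of the three numbers, though every step to it lies within the scatter: a 1.8-fold higher number from compound 1 to compound 3 (0.24 log units; within the scatter) and a 1.1-fold higher number from compound 2 to compound 3 (0.03 log units; within the scatter). Compound 4 `CC(C)(COC(=O)[C@@H](N)c1ccccc1)COC1(c2ccc(Cl)cc2)c2ccccc2C(=O)N1Cc1ccc(Cl)cc1` differs from compound 3 by amino(phenyl)methyl in place of methyl on a carbonyl carbon. For the measured compounds named here, the closest precedent is the step from the amino acid ester of compound 1 to the acetyl ester, a 1.8-fold higher number from compound 1 to compound 3 (0.24 log units; within the scatter), which was small; the reverse direction, back to an amino-bearing ester, is therefore expected to lower the number only slightly, if at all, in this assay. Compound 4 is estimated at 45000 nM, within 20000 nM to 100000 nM, a step of a 1.6-fold lower number from compound 3 to compound 4 (0.19 log units; within the scatter) expected to stay inside the scatter.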

Compound 4, concentration for 50% growth inhibition: 38000 nM
For compound 4 the middle estimate is 1.2-fold (0.07 log units) above the measured one; the range from low to high includes it.
By their numbers in this assay, from the lowest: compounds 4, 1, 2 and 3 (each within the scatter of the next).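

At the carbonyl carbon of this ester, amino(phenyl)methyl in place of methyl, bringing an aromatic ring and a defined stereocentre, stays within the scatter in this assay: a 1.8-fold lower number from compound 3 to compound 4 (0.27 log units; within the scatter), and a 1.7-fold lower number from compound 2 to compound 4 (0.23 log units; within the scatter). Phenyl in place of isopropyl on the chain carbon bound to the amine nitrogen and the carbonyl carbon also stays within it, a 1.1-fold lower number from compound 1 to compound 4 (0.02 log units; within the scatter). No evidence bearing on these readings is available. The compounds shown leave open whether a carboxylic acid or a longer chain carrying an amine at this position would give a step beyond the scatter.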